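Removing the methyl ether from the alkyne side chain

This account rests on a few compounds, and the source may have more. Where it says the series, first, only, none or still open, it means among the compounds named here.

Measured in an ADME assay (liver) for metabolic stability, with Liver microsome (Rattus norvegicus) as the target, using microsomes and NADPH, with a stated time of 30 min, at 37 degrees C, tested at 1 uM; a higher number here means faster removal of the compound, a lower number slower removal:
- Compound 1 `N#Cc1cc(C(O)(C(F)(F)F)C(F)(F)F)cnc1-c1ccc(S(=O)(=O)c2ccc(N)nc2)cc1`: 27 mL.min-1.g-1
- Compound 2 `Nc1ccc(S(=O)(=O)c2ccc(-c3ncc(C(O)(C(F)(F)F)C(F)(F)F)cc3C#CCO)cc2)cn1`: 36 mL.min-1.g-1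
- Compound 3 `COCC#Cc1cc(C(O)(C(F)(F)F)C(F)(F)F)cnc1-c1ccc(S(=O)(=O)c2ccc(N)nc2)cc1`: > 399 mL.min-1.g-1

Compound 3 gives > 399 mL.min-1.g-1, which is a limit of this assay and not a number. For the measured compounds named here, the series holds only one such reading: the limit of > 399 mL.min-1.g-1 in this assay, at which 1 of the 3 values shown sits.

Compound 4 `CC(C)(O)C#Cc1cc(C(O)(C(F)(F)F)C(F)(F)F)cnc1-c1ccc(S(=O)(=O)c2ccc(N)nc2)cc1` is the next case, and it has not yet been measured. It differs from compound 3 at one place: 1-hydroxy-1-methylethyl in place of methoxymethyl on a triple-bonded carbon. In words, this is 1-hydroxy-1-methylethyl in place of methoxymethyl on a triple-bonded carbon.

The closest measured step is an at least 11-fold higher number from compound 2 to compound 3 (1.04 log units; beyond the scatter), where methyl replaces hydrogen on an oxygen on a saturated carbon. The change from nitrile to the methyl ether chain is of similar size: an at least 14-fold higher number from compound 1 to compound 3 (1.16 log units; beyond the scatter). By contrast, the change from nitrile to the free hydroxy chain stays small: a 1.3-fold higher number from compound 1 to compound 2 (0.12 log units; within the scatter).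

Compound 4 has a free hydroxy, so it is read with compound 2 at 36 mL.min-1.g-1 rather than with the methyl ether. Going by the values given here, no measured compound carries the 3-hydroxy-3-methylbut-1-yn-1-yl group, so the range is kept wide.

A large fall in the number is expected: an at least 8.8-fold lower number from compound 3 to compound 4 (0.94 log units; beyond the scatter).

Compound 4 is estimated at 45 mL.min-1.g-1, with an expected range of 15 mL.min-1.g-1 to 150 mL.min-1.g-1.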

Compound 4, intrinsic clearance in microsomes: < 14 mL.min-1.g-1
Compound 4 was reported as a limit (the forecaster's own chance of this, stated with the estimate: 5%); middle value at least 3.2-fold (0.50 log units) away from the limit.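

In this assay the reading for compound 4 is a limit: the limit of < 14 mL.min-1.g-1 in this assay, at which 1 of the 4 values shown sits. Until now, changes at this position had either stayed within the scatter of the nitrile or raised the number sharply, whereas the series now shows an at least 28-fold lower number from compound 3 to compound 4 (1.45 log units; beyond the scatter) and, with 1-hydroxy-1-methylethyl in place of hydroxymethyl on the triple-bonded carbon, an at least 2.5-fold lower number from compound 2 to compound 4 (0.41 log units; beyond the scatter) so the alkyne chain can also take the number past that of the free hydroxy chain of compound 2. Against the nitrile the series shows an at least 1.9-fold lower number from compound 1 to compound 4 (0.28 log units; that floor lies within the scatter) and that floor lies within the scatter, so no order between compound 1 and compound 4 can be claimed from these readings.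

Compound 4 differs from compound 2 by the added methyl groups and from compound 3 by both the free hydroxy and the carbon that carries it, so the shown steps do not separate these two features. A 1-methoxy-1-methylethyl group on the triple-bonded carbon would separate them, and a 1-amino-1-methylethyl group there would test whether the hydroxy itself is needed for the low reading.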